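From Methylsulfanyl to Benzyl: Expected Cytotoxicity Change

The source may report more compounds than this note shows. Statements on the series, on what has been measured and on what is new or still open speak of the compounds shown alone.

Compound 1 `CSc1cccc(NC(=O)C2CCCN(C(=O)c3cc(C(F)(F)F)cc(C(F)(F)F)c3)C2)c1` was examined in an ADME assay on PC-3 cells (Homo sapiens) for cytotoxicity, read by WST assay, tested at 100 uM (on this read-out lower numbers stand for less inhibition and higher numbers for more inhibition at the one concentration tested (going by the name of the read-out)), where compound 1 gives 0%. Compound 2 `COC(=O)c1cccc(C(=O)N2CCCC(C(=O)Nc3ccc(Cl)cc3)C2)c1` gives 0% in this assay, and compound 3 `CS(=O)(=O)Nc1cccc(C(=O)N2CCCC(C(=O)Nc3ccc(Cl)cc3)C2)c1` gives 3%. For the measured compounds named here, the single step between measured compounds that differ in one place, a number 3 percentage points higher from compound 2 to compound 3 (within the scatter), lies within the scatter. Compound 1 stands level with compound 2 at the digits shown, the pair together the lowest of the three numbers, and its gap to compound 3 is also within the scatter, so nothing in the set separates the compounds.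

Compound 4 `O=C(Nc1cccc(Cc2ccccc2)c1)C1CCCN(C(=O)c2cc(C(F)(F)F)cc(C(F)(F)F)c2)C1` differs from compound 1 by benzyl in place of methylsulfanyl on an aromatic carbon. Going by the values given here, no measured step touches this position; the one step on record concerns another part of the core and was within the scatter. Because compound 1 gives 0% and every measured neighbour sits within the scatter of that value, the step of a number 5 percentage points higher from compound 1 to compound 4 (within the scatter) is expected to be small. Compound 4 is therefore estimated at 5%, with a range from -5% to 25%.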

Compound 4, a percentage reported as inhibition, at one concentration (the size of the read-out at that concentration, not a potency): 0%
Beside the measured number, compound 4's estimate is 5 percentage points above it; the range from low to high includes it.
By their numbers in this assay, from the lowest: compounds 1, 2, 4 and 3 (each within the scatter of the next).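

In this assay, the position on an aromatic carbon meta to a large group now has a measured step of its own: benzyl in place of methylsulfanyl gives no change at the digits printed from compound 1 to compound 4 (within the scatter). This change swaps a group of 2 heavy atoms, with sulfur, no ring and 1 hydrogen-bond acceptor, for one of 7 heavy atoms, with a six-membered aromatic ring and no hydrogen-bond acceptor, yet the read-out does not separate the two compounds. Nothing on hand accounts for this result.

The compounds shown leave open whether an amine or a carboxylic acid at this position would also stay within the scatter of compound 1. They also leave open whether a longer chain, such as phenethyl, would give a number that can be told apart from it.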